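The source may report more compounds than this note shows. Statements on the series, on what has been measured and on what is new or still open speak of the compounds shown alone.

Compound 3 `COc1ccc(N/C=C\C(=O)c2cn(-c3ccccc3)nc2-c2ccc(OC)cc2)cc1` gives 13400 nM in a functional assay on PC-3 cells (Homo sapiens) for antiproliferative activity, read by MTT assay, with a stated time of 48 h (a higher number here means a weaker inhibitor, a lower number a stronger inhibitor), and stands at the highest of the three numbers shown. Compound 1 `COc1ccc(-c2nn(-c3ccccc3)cc2C(=O)/C=C\Nc2ccc(F)cc2)cc1` gives 5730 nM and compound 2 `COc1ccc(-c2nn(-c3ccccc3)cc2C(=O)/C=C\Nc2ccc(Cl)cc2)cc1` gives 3890 nM in this assay. The steps of a 2.3-fold higher number from compound 1 to compound 3 (0.37 log units; beyond the scatter) and a 3.4-fold higher number from compound 2 to compound 3 (0.54 log units; beyond the scatter) are modest, while a 1.5-fold lower number from compound 1 to compound 2 (0.17 log units; within the scatter) stays within the scatter. Compound 4 `COc1ccc(N/C=C\C(=O)c2cn(-c3ccccc3)nc2-c2cc(OC)c(OC)c(OC)c2)cc1` differs from compound 3 by 3,4,5-trimethoxyphenyl in place of 4-methoxyphenyl on an aromatic carbon. Going by the values given here, none of the measured steps touches this place: all three exchange the fluoro, chloro or methoxy group at a different aromatic carbon, so nothing measured speaks directly to the move to compound 4. Among the compounds with values here, with no precedent, the expected step of a 1.5-fold lower number from compound 3 to compound 4 (0.17 log units; within the scatter) is kept small and of uncertain direction. Compound 4 is accordingly estimated at 9000 nM, with a range from 2500 nM to 30000 nM.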

Compound 4, half-maximal inhibitory concentration: 9600 nM
The estimate for compound 4 lay 1.1-fold (0.03 log units) below the measured number, and the stated range covers the measured number.
By their numbers in this assay, from the lowest: compounds 2, 1, 4 and 3 (each within the scatter of the next, the first and the last beyond it).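

In this assay, the exchange at the aromatic carbon next to the ring nitrogen gives a 1.4-fold lower number from compound 3 to compound 4 (0.14 log units; within the scatter), so the added methoxy groups leave the reading within the scatter. Unlike the fluoro, chloro and methoxy exchanges at the other aromatic carbon, this change at a second site on the shared core shows no separation between the two compounds. No evidence at hand bears on the reason for this result.

On these data alone, whether 3,4,5-trimethoxyphenyl behaves the same way alongside the fluoro or chloro groups of compound 1 and compound 2 remains open. So does the outcome with a carboxylic acid or an amine on that phenyl ring.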